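This account rests on a few compounds, and the source may have more. Where it says the series, first, only, none or still open, it means among the compounds named here.

The shared core appears in compound 1 `CC[C@H](C)[C@H](N)CN(C(=O)[C@@H]1C[C@H]1c1ccc(OC)cc1)c1ccc(-c2ccccc2)cc1`, compound 2 `CC[C@H](C)[C@H](N)CN(C(=O)[C@@H]1C[C@H]1c1cc(F)cc(F)c1)c1ccc(-c2ccccc2)cc1` and compound 3 `CC[C@H](C)[C@H](N)CN(C(=O)[C@@H]1C[C@H]1c1cncnc1)c1ccc(-c2ccccc2)cc1`, the three differing only in the group on the saturated ring carbon. In a functional assay for agonist activity at G protein-coupled receptor 88 (Homo sapiens), read by HTRF and cAMP accumulation (a higher number here means that more compound is needed for the effect, a lower number that less compound is needed), compound 3 gives 19000 nM, the highest of the two numbers in hand. Compound 2 gives 960 nM in this assay. For compound 1 this assay reports only a limit, > 25000 nM. That limit is the limit of > 25000 nM in this assay, at which 1 of the 3 values shown sits. The step of a 20-fold higher number from compound 2 to compound 3 (1.30 log units; beyond the scatter) is large, whereas an at least 1.3-fold lower number from compound 1 to compound 3 (0.11 log units; that floor lies within the scatter) has its floor inside the scatter. Compound 4 `CC[C@H](C)[C@H](N)CN(C(=O)[C@@H]1C[C@H]1c1ccsc1)c1ccc(-c2ccccc2)cc1` differs from compound 3 by thiophen-3-yl in place of pyrimidin-5-yl on a saturated ring carbon. Swaps at this position have moved this assay by as much as an at least 26-fold lower number from compound 1 to compound 2 (1.41 log units; beyond the scatter), so a step of a 4.8-fold lower number from compound 3 to compound 4 (0.68 log units; beyond the scatter) toward a lower number is expected. Compound 4 is estimated at 4000 nM, within 1000 nM to 20000 nM.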

Compound 4, half-maximal effective concentration: 450 nM
Estimate against measurement, compound 4: 8.9-fold (0.95 log units) above, and the stated range ends above it.
By their numbers in this assay, from the lowest: compound 4; then compound 2; then compound 3. At a limit, above all of these: compound 1.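

In this assay, a six-membered aromatic ring is not needed on the saturated ring carbon, as thiophen-3-yl gives the step of a 42-fold lower number from compound 3 to compound 4 (1.63 log units; beyond the scatter). The step of a 2.1-fold lower number from compound 2 to compound 4 (0.33 log units; beyond the scatter) also puts thiophen-3-yl modestly ahead of 3,5-difluorophenyl. The step of an at least 55-fold lower number from compound 1 to compound 4 (1.74 log units; beyond the scatter) is only a floor, since one end of it is a limit of the assay: the limit of > 25000 nM in this assay, at which 1 of the 4 values shown sits.

Thiophen-3-yl and pyrimidin-5-yl differ in both ring size and hetero atoms, so the compounds shown do not separate these two changes. On these data alone, how furan-3-yl, thiophen-2-yl or a saturated cyclohexyl group would behave at this position remains open.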